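Adding a Methyl on the Ether Chain of Compound 2

The source may hold more compounds than are shown below. What is called first, only, known or untested is meant among the compounds shown, and "the series" means these compounds.

Compound 1 `COc1cc2nc(N3CCC(OCCO)CC3)nc(N)c2cc1OC` and compound 2 `COc1cc2nc(N3CCC(OCC(C)OC)CC3)nc(N)c2cc1OC` share one core. Within the data shown here, in an assay on brain for displacement of a labelled ligand from Adrenergic receptor alpha-1 (Rattus norvegicus) (on this read-out lower numbers stand for stronger inhibition and higher numbers for weaker inhibition), compound 1 gives 2.2 nM, and compound 2 gives 1.41 nM, with compound 1 as the only other measured number; the single measured step, a 1.6-fold lower number from compound 1 to compound 2 (0.19 log units; within the scatter), lies within the scatter. Compound 3 `COc1cc2nc(N3CCC(OCC(C)(C)OC)CC3)nc(N)c2cc1OC` differs from compound 2 by methyl in place of hydrogen on a saturated chain carbon bound to an oxygen on a saturated carbon and two saturated chain carbons. That earlier step bears on this change only loosely, as it also altered the same chain without moving the number beyond the scatter, so compound 3 is expected to stay close to compound 2 in this assay, with an expected step of a 1.1-fold higher number from compound 2 to compound 3 (0.05 log units; within the scatter). The estimate for compound 3 is 1.6 nM, within 0.6 nM to 4.5 nM.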

Compound 3, inhibition constant: 1.14 nM
Beside the measured number, compound 3's estimate is 1.4-fold (0.15 log units) above it, and the stated range covers the measured number.
By their numbers in this assay, from the lowest: compounds 3, 2 and 1 (each within the scatter of the next).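

In this assay methyl in place of hydrogen on this saturated chain carbon gives a 1.2-fold lower number from compound 2 to compound 3 (0.09 log units; within the scatter) and so shows that the 2-methoxy-2-methylpropoxy chain holds the number as closely as the 2-methoxypropoxy chain does. The larger change at the end of the chain, read as a 1.9-fold lower number from compound 1 to compound 3 (0.29 log units; within the scatter) also stays within the scatter, so the three compounds cannot be ranked. Nothing available explains this result. The compounds shown leave open whether an amine, a carboxylic acid or a longer chain at this place would move the number beyond the scatter.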